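The compounds below may be only part of what the source reports. "The series", "measured", "known", "first", "only" and "open" are said of these compounds alone.

In an ADME assay on SH-SY5Y cells (Homo sapiens) for cytotoxicity, read by MTT assay, with a stated time of 72 h (a higher number here means a weaker inhibitor, a lower number a stronger inhibitor), compound 1 `COc1ccc(C(=O)N2CCN(CC(=O)N3CCN(CCCc4c[nH]c5ccccc45)CC3)CC2)cc1` gives 148000 nM and compound 2 `O=C(CN1CCN(C(=O)c2ccc(Cl)cc2)CC1)N1CCN(CCCc2c[nH]c3ccc(F)cc23)CC1` gives 125000 nM and so sits within the usual scatter of compound 1. Compound 3 `COc1ccc(C(=O)N2CCN(CC(=O)N3CCN(CCCc4c[nH]c5ccc(F)cc45)CC3)CC2)cc1` has not yet been measured and differs from compound 2 by methoxy in place of chloro on an aromatic carbon in one place, with methoxy in place of chloro on an aromatic carbon. For the measured compounds named here, no step between measured compounds speaks to this change, so in this assay no shift beyond the scatter is expected in either direction. The estimated change is a 1.1-fold higher number from compound 2 to compound 3 (0.03 log units; within the scatter) and stays within that scatter. Compound 3 is expected at 135000 nM with an estimated range from 70000 nM to 230000 nM in this measurement.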

Compound 3, half-maximal inhibitory concentration: 161000 nM
Compound 3: middle estimate off by 1.2-fold (0.08 log units), on the low side; measured number inside the range.
By their numbers in this assay, from the lowest: compounds 2, 1 and 3 (each within the scatter of the next).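

In this assay, going from 4-chlorophenyl to 4-methoxyphenyl, on an aromatic carbon para to a large group, gives a 1.3-fold higher number from compound 2 to compound 3 (0.11 log units; within the scatter). Fluoro in place of hydrogen on an aromatic carbon, with the methoxy group kept, gives a 1.1-fold higher number from compound 1 to compound 3 (0.04 log units; within the scatter), so neither single change separates these compounds. No supporting measurement bears on these results.

As far as these compounds go, it remains open whether an amine or a carboxylic acid at this place on the ring would move the number beyond the scatter. Whether these two changes would also stay this small on a different core is also unknown.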